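Methoxy in place of methyl on compound 2

The compounds below may be only part of what the source reports. "The series", "measured", "known", "first", "only" and "open" are said of these compounds alone.

Two compounds carry measurements so far: compound 1 (`COc1ccc(-c2noc(CCCCCCC(=O)NO)n2)cc1`) and compound 2 (`Cc1ccc(-c2noc(CCCCCCC(=O)C(F)(F)F)n2)cc1`). In a functional assay on U-937 cells (Homo sapiens) for antiproliferative activity, read by MTT assay, with a stated time of 72 h (a higher number here means a weaker inhibitor, a lower number a stronger inhibitor), compound 1 gives 3650 nM and compound 2 gives 3730 nM in the same read-out. Compound 2 therefore stands level with compound 1, since the two values lie within the scatter of each other. Two numbers offer no wider spread against which to place it.

The next compound is compound 3 (`COc1ccc(-c2noc(CCCCCCC(=O)C(F)(F)F)n2)cc1`), with methoxy in place of methyl on an aromatic carbon, para to a large group. The change from compound 2 is methoxy in place of methyl on an aromatic carbon and the rest of the structure stays the same.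

Among the measured compounds shown here, no measured pair shows this change, and the data point in neither direction. The expectation in this assay is no step beyond the scatter, taking compound 2 at 3730 nM as the starting point. The estimated step is a 1.1-fold lower number from compound 2 to compound 3 (0.03 log units; within the scatter) and would count as no real change. For compound 3 the estimated value is 3500 nM (expected range 1500 nM to 8000 nM).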

Compound 3, half-maximal inhibitory concentration: 1170 nM
Beside the measured number, compound 3's estimate is 3.0-fold (0.48 log units) above it; the whole stated range lies above it.
By their numbers in this assay, from the lowest: compound 3; then compounds 1 and 2 (each within the scatter of the next).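

In this assay, the aromatic carbon para to a large group responds to substitution: with trifluoromethyl on the carbonyl carbon, methoxy in place of methyl gives a 3.2-fold lower number from compound 2 to compound 3 (0.50 log units; beyond the scatter). With methoxy held fixed on the ring, the carbonyl end also matters, as trifluoromethyl in place of hydroxyamino on the carbonyl carbon gives a 3.1-fold lower number from compound 1 to compound 3 (0.49 log units; beyond the scatter), a modest step of about the same size. The level standing of compound 1 and compound 2 could not show either effect. Those two compounds differ in two places. No measurement at hand bears on what lies behind either step.

Open is whether methoxy in place of methyl gives a similar step when hydroxyamino sits on the carbonyl carbon, since the compounds shown test this change only with trifluoromethyl there. Also open, from the compounds shown here alone, is how other groups at this ring position would read in this assay, such as an ethoxy, a chlorine or a dimethylamino group, and whether a shorter or longer chain would keep the step.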